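Removing the methoxy group from compound 3

This account rests on a few compounds, and the source may have more. Where it says the series, first, only, none or still open, it means among the compounds named here.

Values measured in a functional assay (aorta) with Oryctolagus cuniculus as the target (a lower number here means tighter binding, a higher number weaker binding), so far:
- Compound 1 `COc1ccc(C(c2ccc(OC)cc2)C2CCN(CCCOc3ccc(C(C)=O)cc3OC)CC2)cc1` gives 10 nM
- Compound 2 `COc1cc(C(C)O)ccc1OCCCN1CCC(C(c2ccc(F)cc2)c2ccc(F)cc2)CC1` gives 10 nM
- Compound 3 `COc1cc(C#N)ccc1OCCCN1CCC(C(c2ccc(F)cc2)c2ccc(F)cc2)CC1` gives 2 nM

Compound 3 has the lowest number of the three in this assay at 2 nM and is the reference here. Compound 4 `N#Cc1ccc(OCCCN2CCC(C(c3ccc(F)cc3)c3ccc(F)cc3)CC2)cc1` differs from it by hydrogen in place of methoxy on an aromatic carbon, turning 4-cyano-2-methoxyphenoxy into 4-cyanophenoxy. Among the measured compounds shown here, the only measured step, a 5.0-fold lower number from compound 2 to compound 3 (0.70 log units; beyond the scatter), exchanges 1-hydroxyethyl for cyano and does not involve the methoxy group. For the measured compounds named here, it therefore gives only a rough scale, and no measured pair shows this change directly. A modest move towards a higher number is expected, with the estimated step being a 2.5-fold higher number from compound 3 to compound 4 (0.40 log units; beyond the scatter) in this series. For compound 4 the estimated value is 5 nM with an expected range from 1.5 nM to 20 nM in this read-out.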

Compound 4, dissociation constant: 5.01 nM
Compound 4: middle estimate off by 1.0-fold (0.00 log units), on the low side; measured number inside the range.
By their numbers in this assay, from the lowest: compound 3; then compounds 4, 1 and 2 (each within the scatter of the next).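

In this assay, among the compounds shown here, this is the first direct reading of the methoxy position: hydrogen in its place gives a 2.5-fold higher number from compound 3 to compound 4 (0.40 log units; beyond the scatter), so a low number survives without the methoxy group, though its loss is a real, modest step. The wider exchange of 4-(1-hydroxyethyl)-2-methoxyphenyl for 4-cyanophenyl gives a 2.0-fold lower number from compound 2 to compound 4 (0.30 log units; within the scatter), so the two compounds cannot be separated. No measurement available here explains the methoxy step. The compounds shown leave open how ethoxy, fluorine or hydroxyl would read at this place. On these data alone, whether the step holds alongside other groups, such as the acetyl of compound 1, also stays open.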